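The source may report more compounds than this note shows. Statements on the series, on what has been measured and on what is new or still open speak of the compounds shown alone.

Measured so far:
- compound 1 `CC(C)c1c(C(=O)N(C)Cc2ccccc2)nn(-c2ccc(F)cc2)c1OC[C@@H](O)C[C@@H](O)CC(=O)O`: 6720 nM
- compound 2 `CC(C)c1c(C(=O)NCc2cccc(Cl)c2)nn(-c2ccc(F)cc2)c1OC[C@@H](O)C[C@@H](O)CC(=O)O`: "not determined" (no result reported)

Going by the values given here, in a functional assay on L6 cells (Rattus norvegicus) for inhibition (on this read-out higher numbers stand for weaker inhibition and lower numbers for stronger inhibition), compound 1 gives 6720 nM, the only number so far. For compound 2 the entry in this assay is "not determined" (no result reported), so no comparison between the two measured compounds can be drawn, and compound 1 stands alone as the single reference point.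

Compound 3 `CC(C)c1c(C(=O)N(C)Cc2cccc(F)c2)nn(-c2ccc(F)cc2)c1OC[C@@H](O)C[C@@H](O)CC(=O)O` is the next compound to be measured in this assay. It differs from compound 1 in one place: fluoro in place of hydrogen on an aromatic carbon. The change is benzyl to 3-fluorobenzyl, one heavy atom entering on an aromatic carbon meta to a large group, with no change in ring count, donors or acceptors.

Among the compounds with values here, with no step between measured compounds to lean on, the step of a 1.2-fold lower number from compound 1 to compound 3 (0.09 log units; within the scatter) is expected to stay within the usual scatter, with no clear direction. Compound 3 is accordingly estimated at 5500 nM in this assay, within a range of 2000 nM to 15000 nM.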

Compound 3, half-maximal inhibitory concentration: 2470 nM
Estimate against measurement, compound 3: 2.2-fold (0.35 log units) above; measured number inside the range.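

In this assay the series now has its first readable step, a 2.7-fold lower number from compound 1 to compound 3 (0.43 log units; beyond the scatter), and it gives the change from benzyl to 3-fluorobenzyl a direction: toward stronger inhibition, modest in size but beyond the scatter. A single fluoro on this aromatic carbon is therefore accepted without loss of inhibition, and this position of the benzyl ring can shift the read-out, which compound 1 alone could not show. This rests on one pair of compounds, and nothing available here speaks to what lies behind the step.

From the compounds shown here alone, whether chloro, trifluoromethyl, methoxy or nitrile in place of the fluoro would move the number further in the same direction stays open. So does the effect of a carboxylic acid or an amine on this same aromatic carbon.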